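Sulfonyl replacing carbonyl on the shared core

A few compounds are considered here, and "the series" means these few. Any claim that something is new, unique, unknown or untested is made for them only; others in the source may bear on it.

Measured in a functional assay on A-375 cells (Homo sapiens) for cytotoxicity, read by MTT assay; a lower number here means a stronger inhibitor, a higher number a weaker inhibitor:
compound 1 `O=S(=O)(NCCCNc1nccc(-c2c(-c3cccc(F)c3)nc3sccn23)n1)c1ccc(Br)cc1` gives 7040 nM
compound 2 `O=S(=O)(NCCCNc1nccc(-c2c(-c3cccc(F)c3)nc3sccn23)n1)c1ccc(C(F)(F)F)cc1` gives 4090 nM
compound 3 `O=C(NCCNc1nccc(-c2c(-c3cccc(F)c3)nc3sccn23)n1)c1ccc(C(F)(F)F)cc1` gives 8710 nM

Compound 3 returns the highest of the three numbers. Compound 1 stands nearest to it, within the scatter, while compound 2 stands furthest, beyond the scatter. Compound 4 `O=S(=O)(NCCNc1nccc(-c2c(-c3cccc(F)c3)nc3sccn23)n1)c1ccc(F)cc1` is not yet measured; its change from compound 3 is (4-fluorophenyl)sulfonyl in place of (4-(trifluoromethyl)phenyl)carbonyl on an amine nitrogen.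

Going by the values given here, the one measured step, a 1.7-fold lower number from compound 1 to compound 2 (0.24 log units; within the scatter), exchanges one group for another on the aromatic ring of a sulfonyl-bearing compound and does not touch the carbonyl-to-sulfonyl exchange, so no measured pair bears on that exchange directly. Among the compounds with values here, compounds 2 and 3 differ in more than one place; their two values show only that the sulfonyl-bearing compound 2 returns the lower number.

Compounds 1 and 2 mark where two sulfonyl-bearing members of the series lie, and compound 4 is expected to fall in that region. For compound 4 the expected step is a 1.5-fold lower number from compound 3 to compound 4 (0.18 log units; within the scatter), a modest lowering that need not clear the scatter. The estimate for compound 4 in this assay is 5800 nM, with a range from 2500 nM to 13000 nM.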

Compound 4, half-maximal inhibitory concentration: 9450 nM
Compound 4: middle estimate off by 1.6-fold (0.21 log units), on the low side; measured number inside the range.
By their numbers in this assay, from the lowest: compounds 2, 1, 3 and 4 (each within the scatter of the next, the first and the last beyond it).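

In this assay the exchange of (4-(trifluoromethyl)phenyl)carbonyl for (4-fluorophenyl)sulfonyl on the amine nitrogen gives a 1.1-fold higher number from compound 3 to compound 4 (0.04 log units; within the scatter), so at this position the two groups are not told apart by this read-out. The step of a 1.3-fold higher number from compound 1 to compound 4 (0.13 log units; within the scatter), with ((4-fluorophenyl)sulfonyl)amino in place of (((4-bromophenyl)sulfonyl)amino)methyl, also stays within the scatter, and neither change moves the number measurably. No measurement at hand offers a reason for either result.

Compound 4 changes the sulfonyl and the ring substituent together, so the carbonyl-to-sulfonyl exchange on its own remains unresolved. Also open, from the compounds shown here alone, is whether an amine or a carboxylic acid on the aromatic ring, or a longer chain, would give a step beyond the scatter.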